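Propyl to Tert-Butyl: A Step Expected to Stay Flat

The source may report more compounds than this note shows. Statements on the series, on what has been measured and on what is new or still open speak of the compounds shown alone.

Compound 1 `Cc1ccc(C(=O)C2=C(O)C(=O)N(CC(C)O)C2c2cccc(C(C)C)c2)cc1` gives 100% in an assay on isolated protein for inhibition of annexin A2/S100-A10 (Homo sapiens), with a stated time of 5 min, tested at 50 uM (a lower number here means less inhibition, a higher number more inhibition at the concentration tested (going by the name of the read-out)), and compound 2 `CCCc1ccc(C2C(C(=O)c3ccc(C)cc3)=C(O)C(=O)N2CC(C)O)cc1` gives 97%; compound 2 stands alongside compound 1, the two numbers within the scatter of each other. For the measured compounds named here, the only measured step, a number 3 percentage points lower from compound 1 to compound 2 (within the scatter), is a swap of the whole group, 4-propylphenyl in place of 3-isopropylphenyl, and it did not move the number beyond the scatter. Compound 3 `Cc1ccc(C(=O)C2=C(O)C(=O)N(CC(C)O)C2c2ccc(C(C)(C)C)cc2)cc1` differs from compound 2 by tert-butyl in place of propyl on an aromatic carbon, a smaller alteration of the same kind of group, so no step beyond the scatter is expected. Compound 3 is therefore estimated at 95%, between 80% and 100%. The expected step is a number 2 percentage points lower from compound 2 to compound 3 (within the scatter).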

Compound 3, a percentage reported as inhibition, at one concentration (the size of the read-out at that concentration, not a potency): 123%
Compound 3: middle estimate off by 28 percentage points, on the low side; measured number outside the range, above it.
By their numbers in this assay, from the lowest: compounds 2 and 1 (each within the scatter of the next); then compound 3.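

In this assay tert-butyl in place of propyl on an aromatic carbon gave a number 26 percentage points higher from compound 2 to compound 3 (beyond the scatter) and so showed that changing one group at this place can move the number beyond the scatter, which the earlier pair had not shown. The swap to 4-(tert-butyl)phenyl from 3-isopropylphenyl gave a number 23 percentage points higher from compound 1 to compound 3 (beyond the scatter) as well, so the rise holds against both earlier compounds. No measurement at hand accounts for this rise.

On these data alone, whether it belongs to tert-butyl alone or would also appear with a cyclohexyl group at this place remains open. So does the outcome with an amine or a carboxylic acid on that aromatic carbon.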